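From biphenyl amide to dimethylphenyl amide on a shared core

The compounds below may be only part of what the source reports. "The series", "measured", "known", "first", "only" and "open" are said of these compounds alone.

Compound 1, `Cc1ccc(Nc2ncc3c(n2)N(C)C(=O)N(c2cc(NC(=O)c4cccc(C(F)(F)F)c4)ccc2C)C3)cc1N`: 3 nM
Compound 2, `Cc1ccc(Nc2ncc3c(n2)N(C)C(=O)N(c2cc(NC(=O)c4cccc(-c5ccccc5)c4)ccc2C)C3)cc1N`: 23 nM

In a functional assay on K562 cells (Homo sapiens) for antiproliferative activity, read by CellTiter-Glo and CCK-8 assay, with a stated time of 72 h (on this read-out higher numbers stand for weaker inhibition of growth and lower numbers for stronger inhibition of growth), compound 1 gives 3 nM, and compound 2 gives 23 nM. Among the compounds with values here, the one measured step is a 7.7-fold higher number from compound 1 to compound 2 (0.88 log units; beyond the scatter), so compound 2 stands at the higher of the two numbers. Compound 3, `Cc1cc(C)cc(C(=O)Nc2ccc(C)c(N3Cc4cnc(Nc5ccc(C)c(N)c5)nc4N(C)C3=O)c2)c1`, differs from compound 2 by 3,5-dimethylphenyl in place of 3-phenylphenyl on a carbonyl carbon. Within the data shown here, only the step of a 7.7-fold higher number from compound 1 to compound 2 (0.88 log units; beyond the scatter) bears on this change; it shows that the group on that carbonyl carbon shifts the number beyond the scatter. Compound 3 returns to a single ring at that position, as compound 1 has, though with different substitution, so its number is expected to fall between those of compound 1 and compound 2, a modest step downward from compound 2, a 2.3-fold lower number from compound 2 to compound 3 (0.36 log units; beyond the scatter). Compound 3 is therefore estimated at 10 nM, with a range from 3 nM to 40 nM.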

Compound 3, concentration for 50% growth inhibition: 26 nM
Compound 3: middle estimate off by 2.6-fold (0.41 log units), on the low side; low and high end bracket the measured number.
By their numbers in this assay, from the lowest: compound 1; then compounds 2 and 3 (each within the scatter of the next).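

In this assay, the change on the carbonyl carbon from 3-phenylphenyl to 3,5-dimethylphenyl gives a 1.1-fold higher number from compound 2 to compound 3 (0.05 log units; within the scatter), so a group with one aromatic ring instead of two leaves the number within the scatter. A single aromatic ring is therefore not enough to recover the low number of compound 1: replacing 3-(trifluoromethyl)phenyl with 3,5-dimethylphenyl gives an 8.7-fold higher number from compound 1 to compound 3 (0.94 log units; beyond the scatter), and among these three compounds only 3-(trifluoromethyl)phenyl stands apart. No measurement here accounts for this difference.

The compounds shown leave open whether the gap depends on trifluoromethyl itself or on the ring carrying one substituent rather than two. A phenyl ring with a single methyl, a chlorine or a morpholine on it would help to separate these two readings.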